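Tert-butyl replaces 3-methoxyphenyl on a compound without a number

The compounds below may be only part of what the source reports. "The series", "measured", "known", "first", "only" and "open" are said of these compounds alone.

In a functional assay on HCT-116 cells (Homo sapiens) for cytotoxicity, read by a luciferase reporter and CellTiter-Glo, with a stated time of 72 h (a higher number here means a weaker inhibitor, a lower number a stronger inhibitor), compound 1 `COc1cccc(C2=NN(c3cccc(Cl)c3)C(c3ccc(Cl)cc3)C2)c1` stands as "not determined" (no result reported) and compound 2 `COc1cccc(C2=NN(c3ccc(Cl)cc3)C(c3ccc(Cl)cc3)C2)c1` stands as "not determined" (no result reported) so neither has a number to compare. The starting point of this step therefore has no measured standing. Among the measured compounds shown here, the only number comes from compound 3 `COc1cccc(C2=NN(c3ccc(Cl)cc3)C(c3cccc(Cl)c3)C2)c1` at 18500 nM in this assay and it belongs to a different compound. Compound 4 `CC(C)(C)C1=NN(c2ccc(Cl)cc2)C(c2ccc(Cl)cc2)C1` has not yet been measured. For the measured compounds named here, the single structural change is tert-butyl in place of 3-methoxyphenyl on a carbon with a double bond to nitrogen with tert-butyl in place of 3-methoxyphenyl on a carbon with a double bond to nitrogen. With compound 3 at 18500 nM as the only anchor, no step beyond the scatter is expected in this assay in either direction. Compound 4 is expected near 20000 nM (estimated range 6000 nM to 60000 nM).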

Compound 4, half-maximal inhibitory concentration: 17300 nM
Estimate against measurement, compound 4: 1.2-fold (0.06 log units) above, within the range that was stated.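

Compound 4 gives a number in this assay but compound 2 offers none to set against it, so no step can be read between them. The compounds shown leave open what tert-butyl in place of 3-methoxyphenyl does to potency, and no supporting evidence bears on this result.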